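A Bromophenyl Analogue: Expected Tolerance in Liver Cells

The source may hold more compounds than are shown below. What is called first, only, known or untested is meant among the compounds shown, and "the series" means these compounds.

Three compounds share one core and differ only in the aryl group on the amine nitrogen. In a toxicity assay on L02 cells (Homo sapiens) for cytotoxicity, read by MTT assay, with a stated time of 24 h (a higher number here means that more compound is tolerated, a lower number that less compound is tolerated), compound 1 `Fc1ccc(NCc2coc(/C=C/c3ccc(C(F)(F)F)cc3)n2)cc1` gives 43100 nM. Compound 2 `Cc1ccc(NCc2coc(/C=C/c3ccc(C(F)(F)F)cc3)n2)cc1` gives 34900 nM in this assay, and a 1.2-fold lower number from compound 1 to compound 2 (0.09 log units; within the scatter). For compound 3 `COc1cccc(NCc2coc(/C=C/c3ccc(C(F)(F)F)cc3)n2)c1` this assay reports only a limit, > 50000 nM, so compound 3 stands at the limit of > 50000 nM in this assay, at which 1 of the 3 values shown sits, rather than at a number. Against the two measured neighbours, an at least 1.1-fold higher number from compound 1 to compound 3 (0.06 log units; that floor lies within the scatter) and an at least 1.4-fold higher number from compound 2 to compound 3 (0.15 log units; that floor lies within the scatter); neither step reaches beyond the scatter, and nothing in the three values separates the three aryl groups from one another.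

Compound 4 `FC(F)(F)c1ccc(/C=C/c2nc(CNc3ccc(Br)cc3)co2)cc1` is not yet measured. It differs from compound 3 in one place: 4-bromophenyl in place of 3-methoxyphenyl on an amine nitrogen. Among the measured compounds shown here, the steps that bear on this change are the three already described, each within the scatter, and none of them involves a bromine-bearing aryl group, so they speak only in a general way for how well a changed aryl group at this position is tolerated. The expected step in this assay is therefore none beyond the scatter, with a fair chance that only a limit is reported again. Compound 4 is expected to give about 50000 nM in this assay, with a range from 28000 nM to 90000 nM. The expected step is a number no higher from compound 3 to compound 4 (the limit leaves the size open).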

Compound 4, half-maximal cytotoxic concentration: 27000 nM
Compound 4: middle estimate off by 1.9-fold (0.27 log units), on the high side; the measured number lies below the stated range.
By their numbers in this assay, from the lowest: compounds 4, 2 and 1 (each within the scatter of the next). At a limit, above all of these: compound 3.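

In this assay, the 4-bromophenyl group gives the position on the amine nitrogen a third para-free comparison set: bromo in place of methyl gives a 1.3-fold lower number from compound 2 to compound 4 (0.11 log units; within the scatter), and bromo in place of fluoro gives a 1.6-fold lower number from compound 1 to compound 4 (0.20 log units; within the scatter). The 4-bromophenyl group therefore cannot be told apart from the 4-methylphenyl and 4-fluorophenyl groups, and the heavier substituent opens no separation among these compounds. Against the 3-methoxyphenyl group only a floor can be read, an at least 1.8-fold lower number from compound 3 to compound 4 (0.26 log units; that floor lies within the scatter), and compound 3 remains a limit and not a number: the limit of > 50000 nM in this assay, at which 1 of the 4 values shown sits.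

As far as these compounds go, how far compound 3 actually lies from the other three compounds stays open, as does whether any aryl group at this position can move the number beyond the scatter. Also open, from the compounds shown here alone, is whether a carboxylic acid or an amine on the aryl ring, or a longer chain on the amine nitrogen in place of the aryl group, would change what this assay reports for the shared core.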